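This account rests on a few compounds, and the source may have more. Where it says the series, first, only, none or still open, it means among the compounds named here.

Measured in a functional assay on cells for antagonist activity at prostaglandin E2 receptor EP1 subtype (Rattus norvegicus), read by fluorescence and calcium flux, with a stated time of 60 s; a higher number here means a weaker inhibitor, a lower number a stronger inhibitor:
Compound 1 `O=C(O)c1cccc(Cc2c(-c3cccc(Cl)c3)nn3cc(Cl)ccc23)n1` gives 480 nM.
Compound 2 `CC(C)Cc1nn2cc(Cl)ccc2c1Cc1cccc(C(=O)O)n1` gives 200 nM.
Compound 3 `O=C(O)c1cccc(Cc2c(C3CC3)nn3cc(Cl)ccc23)n1` gives 1500 nM.

Compound 1 stands in the middle of these three numbers in this assay: the step of a 2.4-fold lower number from compound 1 to compound 2 (0.38 log units; beyond the scatter) runs downward, the step of a 3.1-fold higher number from compound 1 to compound 3 (0.49 log units; beyond the scatter) runs upward, and both lie beyond the scatter. Compound 4 `O=C(O)c1cccc(Cc2c(N3CCCCC3)nn3cc(Cl)ccc23)n1` has not yet been measured. It differs from compound 1 in one place: piperidin-1-yl in place of 3-chlorophenyl on an aromatic carbon. The two measured steps that start from compound 1 both replace the same 3-chlorophenyl, so they bear on this change, but neither introduces a saturated ring with a nitrogen, and they point in opposite directions. A piperidin-1-yl group is closer in heavy-atom count to the groups of compound 1 and compound 2 than to the cyclopropyl of compound 3, so a step of modest size in either direction is expected, with weakening somewhat more likely than gain. The expected step is a 1.5-fold higher number from compound 1 to compound 4 (0.16 log units; within the scatter). Compound 4 is therefore estimated at 700 nM, with a range from 200 nM to 2500 nM.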

Compound 4, half-maximal inhibitory concentration: 79 nM
The estimate for compound 4 lay 8.9-fold (0.95 log units) above the measured number, and the stated range ends above it.
By their numbers in this assay, from the lowest: compound 4; then compound 2; then compound 1; then compound 3.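

In this assay, piperidin-1-yl gives the lowest number of the four groups placed on this aromatic carbon, with a 6.1-fold lower number from compound 1 to compound 4 (0.78 log units; beyond the scatter) and a 2.5-fold lower number from compound 2 to compound 4 (0.40 log units; beyond the scatter) and a 19-fold lower number from compound 3 to compound 4 (1.28 log units; beyond the scatter) as its steps. Among the compounds shown here, the earlier compounds carried only carbon groups here, so this is the first sign that the position accepts a non-aromatic six-membered ring with a nitrogen, and that such a ring can outdo 3-chlorophenyl, which also holds a six-membered ring. No measurement at hand accounts for this result.

The change from 3-chlorophenyl alters both the ring's aromatic character and its atoms, so the compounds shown do not separate the part played by the nitrogen from that of the non-aromatic ring, a question a cyclohexyl group would address. As far as these compounds go, how a morpholin-4-yl or pyrrolidin-1-yl group would compare at this position also stays open.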